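Ester to acid on the biphenyl of a ROCK2 inhibitor

The compounds below may be only part of what the source reports. "The series", "measured", "known", "first", "only" and "open" are said of these compounds alone.

Of the compounds shown here, two have been measured in an assay on isolated protein for inhibition of Rho-associated protein kinase 2 (Homo sapiens), read by radiometric assay; a lower number here means a stronger inhibitor, a higher number a weaker inhibitor. Compound 1 `CCCCOC(=O)c1cccc(-c2cc(C(=O)Nc3ccncc3)ccc2CN)c1` gives 5.5 nM. Compound 2 `NCc1ccc(C(=O)Nc2ccncc2F)cc1-c1cccc(C(=O)OCC2CCCO2)c1` gives 2.5 nM, the lower of the two numbers, and the gap from compound 1 lies beyond the scatter. Compound 3 `NCc1ccc(C(=O)Nc2ccncc2F)cc1-c1cccc(C(=O)O)c1` is not yet measured; it differs from compound 2 by hydrogen in place of (oxolan-2-yl)methyl on an oxygen next to a carbonyl group. Going by the values given here, no measured pair shows this kind of change, so the expectation rests loosely on compound 2 alone. A modest weakening is expected, from compound 2 to compound 3 a 3.2-fold higher number from compound 2 to compound 3 (0.51 log units; beyond the scatter). Compound 3 is estimated at 8 nM, within 2 nM to 40 nM.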

Compound 3, half-maximal inhibitory concentration: 55 nM
For compound 3 the middle estimate is 6.9-fold (0.84 log units) below the measured one; the whole stated range lies below it.
By their numbers in this assay, from the lowest: compound 2; then compound 1; then compound 3.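

In this assay, the step of a 22-fold higher number from compound 2 to compound 3 (1.34 log units; beyond the scatter) shows that this position is sensitive to the change from ((oxolan-2-yl)methoxy)carbonyl to carboxy. Removing (oxolan-2-yl)methyl from the oxygen next to the carbonyl group is a large step, so potency here depends strongly on what that oxygen carries. No measurement here accounts for the step. From the compounds shown here alone, whether the ring of (oxolan-2-yl)methyl matters or any ester would serve remains open. A methyl ester or a primary carboxamide at this place could help separate those possibilities.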